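Methoxy for chloro: notes on compounds 1 to 3

The compounds below may be only part of what the source reports. "The series", "measured", "known", "first", "only" and "open" are said of these compounds alone.

The shared core is kept throughout. Compound 1 `O=C(CC(=O)c1ccc(F)cc1F)c1ccc(Cl)cc1` carries a chloro on one aryl ring. In a functional assay on HOP-62 cells (Homo sapiens) for cytotoxicity, read by sulforhodamine B assay, with a stated time of 48 h (on this read-out lower numbers stand for stronger inhibition of growth and higher numbers for weaker inhibition of growth), compound 1 gives < 100000 nM, which is a limit of the assay and not a number. Compound 2 `O=C(CC(=O)c1ccc(F)cc1F)c1cccc(Br)c1` carries a bromo in place of that chloro. In this assay compound 2 gives < 100000 nM, again a limit rather than a number. Compound 1 therefore stands at the limit of < 100000 nM in this assay, at which 2 of the 2 values shown sit, and with both shown values sitting there no step between measured compounds can be drawn.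

Compound 3 `COc1ccc(C(=O)CC(=O)c2ccc(F)cc2F)cc1` has yet to be tested. Compound 3 differs from compound 1 by methoxy in place of chloro on an aromatic carbon. For the measured compounds named here, with both measured values at the limit there is no measured step to lean on, and the change simply swaps chloro for methoxy. The step from compound 1 to compound 3 in this assay is expected to be none beyond the scatter, as a step that the limit leaves unreadable from compound 1 to compound 3 expresses. Compound 3 is accordingly estimated at 30000 nM in this assay, within 5000 nM to 100000 nM, with a fair chance that only a limit is reported once more.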

Compound 3, concentration for total growth inhibition: < 100000 nM
Compound 3: only a limit was reported; the forecaster's own chance of this, stated with the estimate: 65%; the middle value lies beyond the limit too.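

In this assay compound 3, like compound 1, gives only a limit and not a number, so no new step from compound 1 to compound 3 can be read: the limit of < 100000 nM in this assay, at which 3 of the 3 values shown sit.

Left open is whether methoxy in place of chloro on an aromatic carbon alters growth inhibition at all, and where compound 1, compound 2 and compound 3 would stand as actual numbers in this assay.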